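Methoxy for Methyl on the Aryl of Compound 2

A few compounds are considered here, and "the series" means these few. Any claim that something is new, unique, unknown or untested is made for them only; others in the source may bear on it.

The two measured compounds share a core that carries a trifluoromethyl-substituted amide and an aryl group on an aromatic nitrogen. Compound 1 `Cc1c(C(=O)Nc2ccc(C(F)(F)F)cc2)cnn1-c1ccc(F)c(Cl)c1` is measured in a functional assay with Homo sapiens as the target (a lower number here means a stronger inhibitor, a higher number a weaker inhibitor), and gives 1300 nM. Compound 2 `Cc1cccc(-n2ncc(C(=O)Nc3ccc(C(F)(F)F)cc3)c2C)c1` gives 2500 nM in this assay. On these two numbers compound 2 stands highest, with compound 1 as its only neighbour, and the step of a 1.9-fold higher number from compound 1 to compound 2 (0.28 log units; within the scatter) is within the scatter, so the two cannot be told apart on the numbers shown.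

Compound 3 `COc1cccc(-n2ncc(C(=O)Nc3ccc(C(F)(F)F)cc3)c2C)c1` is not yet measured. It differs from compound 2 in one place: methoxy in place of methyl on an aromatic carbon. For the measured compounds named here, only one measured step exists, a 1.9-fold higher number from compound 1 to compound 2 (0.28 log units; within the scatter), and it exchanges the whole aryl group rather than a single substituent on it; it bears on the new step only loosely and was itself within the scatter. Going by the values given here, no measured pair shows methoxy against methyl. One therefore expects no step beyond the scatter in this assay, in either direction, the expected step being no change at the digits printed from compound 2 to compound 3 (within the scatter). Compound 3 is estimated at 2500 nM, within a range from 1000 nM to 6300 nM.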

Compound 3, half-maximal inhibitory concentration: 2500 nM
Beside the measured number, compound 3's estimate shows no gap at the digits printed, within the range that was stated.
By their numbers in this assay, from the lowest: compounds 1, 2 and 3 (each within the scatter of the next).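

For the compounds shown here, at the aromatic carbon meta to a large group, methoxy in place of methyl is the first exchange of a single substituent on this aryl group, and in this assay it reads as no change at the digits printed from compound 2 to compound 3 (within the scatter), so the added oxygen and its one hydrogen-bond acceptor leave the number within the scatter. The wider exchange of 3-methoxyphenyl in place of 3-chloro-4-fluorophenyl on the aromatic nitrogen reads as a 1.9-fold higher number from compound 1 to compound 3 (0.28 log units; within the scatter), which places all three aryl groups shown within the scatter of one another. Why methyl and methoxy read alike here cannot be told, as no independent evidence bears on this result.

The compounds shown leave open whether an amine, a carboxylic acid or a longer alkoxy chain on the same aromatic carbon would give a step beyond the scatter in this assay. They also leave open what a nitrile in place of the trifluoromethyl group would do, since that group and the methyl group on the shared core stay the same in all three compounds.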